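Amine side chain: methylamino to ethylamino

The source may hold more compounds than are shown below. What is called first, only, known or untested is meant among the compounds shown, and "the series" means these compounds.

Measured in a functional assay on A2780 cells (Homo sapiens) for antiproliferative activity, read by MTT assay, with a stated time of 48 h (on this read-out higher numbers stand for weaker inhibition and lower numbers for stronger inhibition), so far
- compound 1 `C=C(c1ccc(OC)cc1NC(=O)CN)c1ccc(OC)c2c1C=CC(C)(C)O2` gives 400 nM
- compound 2 `C=C(c1ccc(OC)cc1NC(=O)CNC)c1ccc(OC)c2c1C=CC(C)(C)O2` gives 720 nM
- compound 3 `C=C(c1ccc(OC)cc1NC(=O)CNCC)c1ccc(OC)c2c1C=CC(C)(C)O2` has no value yet

Within the data shown here, only two numbers exist, and compound 2 (720 nM) lies within the scatter of compound 1. Compound 3 turns the methylamino group into ethylamino (methyl in place of hydrogen on a saturated chain carbon bound to an amine nitrogen), with methyl in place of hydrogen on a saturated chain carbon bound to an amine nitrogen. Among the measured compounds shown here, one measured step bears on this, methyl in place of hydrogen on an amine nitrogen (a 1.8-fold higher number from compound 1 to compound 2 (0.26 log units; within the scatter)). It acts on a different atom and stands alone, so it is only a loose guide. It offers no ground for expecting a step beyond the scatter in this assay, and none is expected. The expected step is small (a 1.1-fold higher number from compound 2 to compound 3 (0.05 log units; within the scatter)). Compound 3 is estimated at 800 nM (expected range 380 nM to 1700 nM).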

Compound 3, half-maximal inhibitory concentration: 2010 nM
For compound 3 the middle estimate is 2.5-fold (0.40 log units) below the measured one, outside the stated range (above it).
By their numbers in this assay, from the lowest: compounds 1 and 2 (each within the scatter of the next); then compound 3.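

In this assay, among these compounds, the change from methylamino to ethylamino gives the first step on this side chain that lies beyond the scatter: a 2.8-fold higher number from compound 2 to compound 3 (0.45 log units; beyond the scatter). Measured from the unsubstituted amine, the ethyl group on the amine nitrogen gives a 5.0-fold higher number from compound 1 to compound 3 (0.70 log units; beyond the scatter), while the methyl group on the same nitrogen gave only a 1.8-fold higher number from compound 1 to compound 2 (0.26 log units; within the scatter), so at this position in this assay methyl is tolerated and ethyl brings a loss. Nothing at hand explains why the added carbon raises the number.

On these data alone, whether the number keeps rising with a longer chain such as propyl, or with a branched isopropyl group or a cyclic amine such as pyrrolidine, remains open. A single ethyl example marks where the loss appears, but it does not establish a trend with chain length.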